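Methoxy to methyl swap: cytotoxicity notes on four compounds

This account rests on a few compounds, and the source may have more. Where it says the series, first, only, none or still open, it means among the compounds named here.

Compound 1, `COc1ccccc1[S+]([O-])c1cccc(N)c1C#N`, in a functional assay on MT4 cells (Homo sapiens) for cytotoxicity (a higher number here means a weaker inhibitor, a lower number a stronger inhibitor), gives > 200000 nM, a limit of the assay.
Compound 2, `COc1ccc([S+]([O-])c2cccc(N)c2C#N)cc1`, in this assay gives > 200000 nM, a limit of the assay.
Compound 3, `Cc1ccccc1[S+]([O-])c1cccc(N)c1C#N`, in this assay gives > 200000 nM, a limit of the assay.

Among the compounds with values here, the one measured step, a step that the two limits leave unreadable from compound 1 to compound 3, is the change (methyl in place of methoxy on an aromatic carbon). Its size cannot be read, because of the limit of > 200000 nM in this assay, at which 3 of the 3 values shown sit. Compound 1 and compound 2 have the same atoms joined differently; the difference between the two cores is not broken down here.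

Compound 4, `Cc1ccc([S+]([O-])c2cccc(N)c2C#N)cc1`, is not yet measured in this assay. It differs from compound 2 by methyl in place of methoxy on an aromatic carbon. This is the same kind of change as from compound 1 to compound 3, though the place differs: there the methyl stands ortho to a large group, here para to a large group.

Compound 2 itself sits at a limit, > 200000 nM. With three of three values at that limit and the measured step unreadable, the expected step is a step that the limit leaves unreadable from compound 2 to compound 4. Compound 4 is estimated at 250000 nM, between 100000 nM and 600000 nM, most likely reported again only as a limit.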

Compound 4, half-maximal inhibitory concentration: > 200000 nM
Compound 4: no number, only a limit; the forecaster's own chance of this, stated with the estimate: 85%; the middle value does not contradict the limit.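

Compound 2 and compound 4 yield no readable step for methyl in place of methoxy, and compound 1 and compound 3 yield none either, because all four stand at the same limit: the limit of > 200000 nM in this assay, at which 4 of the 4 values shown sit.

The compounds shown leave open whether this change alters cytotoxicity at all, and whether its place on the ring matters.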